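This account rests on a few compounds, and the source may have more. Where it says the series, first, only, none or still open, it means among the compounds named here.

- Compound 1 `O=C(NCCCCC(c1ccc(F)cc1)c1ccc(F)cc1)Nc1ccc([N+](=O)[O-])cc1`: 6470 nM
- Compound 2 `Nc1ccc(NC(=O)NCCCCC(c2ccc(F)cc2)c2ccc(F)cc2)cc1`: > 20000 nM, a limit
- Compound 3 `O=C(NCCCCC(c1ccc(F)cc1)c1ccc(F)cc1)Nc1cccc([N+](=O)[O-])c1`: 3790 nM

All three were tested in a functional assay on MDA-MB-231 cells (Homo sapiens) for cytotoxicity, read by MTT assay, with a stated time of 48 h; a lower number here means a stronger inhibitor, a higher number a weaker inhibitor. Compound 3 gives 3790 nM, which lies within the scatter of compound 1, with a 1.7-fold lower number from compound 1 to compound 3 (0.23 log units; within the scatter). Compound 2 gives only a limit, > 20000 nM. Measured against that limit, the result is an at least 5.2-fold lower number from compound 2 to compound 3 (0.72 log units; beyond the scatter).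

Compound 4 `Nc1cc(NC(=O)NCCCCC(c2ccc(F)cc2)c2ccc(F)cc2)ccc1Cl` has 3-amino-4-chlorophenyl in place of 3-nitrophenyl on an amide-type nitrogen.

For the measured compounds named here, the nearest precedent is the one exchange of nitro for amino, an at least 3.0-fold higher number from compound 1 to compound 2 (0.49 log units; beyond the scatter). That step points towards a higher number in this assay, and an at least 5.2-fold lower number from compound 2 to compound 3 (0.72 log units; beyond the scatter) points the same way when read in reverse. Going by the values given here, neither is a close match, however, since compound 2 carries 4-aminophenyl and no measured compound contains chlorine. A rise beyond the scatter is therefore expected, though perhaps a smaller one than compound 2 suggests.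

The estimated change is a 2.9-fold higher number from compound 3 to compound 4 (0.46 log units; beyond the scatter). For compound 4 the expected value is 11000 nM, with an estimated range of 4000 nM to 30000 nM.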

Compound 4, half-maximal inhibitory concentration: 9240 nM
Beside the measured number, compound 4's estimate is 1.2-fold (0.08 log units) above it; the measured number falls inside the stated range.
By their numbers in this assay, from the lowest: compounds 3, 1 and 4 (each within the scatter of the next, the first and the last beyond it). At a limit, above all of these: compound 2.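

In this assay the exchange on the amide-type nitrogen gives a 2.4-fold higher number from compound 3 to compound 4 (0.39 log units; beyond the scatter) and so shows that a ring bearing an amino group can still give a full number at this place. Compound 2 stands at a limit, so an at least 2.1-fold lower number from compound 2 to compound 4 (0.33 log units; beyond the scatter) is only a bound: the limit of > 20000 nM in this assay, at which 1 of the 4 values shown sits. Compound 4, with 3-amino-4-chlorophenyl, cannot be told apart from compound 1, with its 4-nitrophenyl, as a 1.4-fold higher number from compound 1 to compound 4 (0.15 log units; within the scatter) lies within the scatter.

Compound 4 differs from compound 3 by both an amino group in place of nitro and an added chlorine, and the compounds shown do not separate these two changes. A plain 3-aminophenyl or a 4-chlorophenyl on the same nitrogen would separate them.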